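Cytotoxicity series: fluoro to trifluoromethyl step

The compounds below may be only part of what the source reports. "The series", "measured", "known", "first", "only" and "open" are said of these compounds alone.

Compound 1 `COc1ccc(C(=O)c2cc(OC)c(OC)c(OC)c2)cc1NC(=O)/C=C/c1ccc(OC)c(OC)c1` gives 8200 nM in a functional assay on COLO 205 cells (Homo sapiens) for cytotoxicity, read by MTT assay, with a stated time of 72 h; on this read-out higher numbers stand for weaker inhibition and lower numbers for stronger inhibition.
Compound 2 `C#CCOc1cccc(/C=C/C(=O)Nc2cc(C(=O)c3cc(OC)c(OC)c(OC)c3)ccc2OC)c1` gives 13400 nM in this assay.
Compound 3 `COc1ccc(C(=O)c2cc(OC)c(OC)c(OC)c2)cc1NC(=O)/C=C/c1ccc(F)cc1` gives 3400 nM in this assay.

Compound 3 stands at the lowest number of the three in this assay: the steps of a 2.4-fold lower number from compound 1 to compound 3 (0.38 log units; beyond the scatter) and a 3.9-fold lower number from compound 2 to compound 3 (0.60 log units; beyond the scatter) both lie beyond the scatter, whereas a 1.6-fold higher number from compound 1 to compound 2 (0.21 log units; within the scatter) does not. Compound 4 `COc1ccc(C(=O)c2cc(OC)c(OC)c(OC)c2)cc1NC(=O)/C=C/c1ccc(C(F)(F)F)cc1` differs from compound 3 by trifluoromethyl in place of fluoro on an aromatic carbon. Within the data shown here, no measured step exchanges one substituent for another while keeping the same aryl ring; every measured step swaps the whole aryl group, and the two that exceed the scatter are modest. Among the measured compounds shown here, with no close precedent, the expected step is a 1.2-fold higher number from compound 3 to compound 4 (0.07 log units; within the scatter), in no firm direction. Compound 4 is therefore estimated at 4000 nM, within a range of 1500 nM to 12000 nM.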

Compound 4, half-maximal inhibitory concentration: 2600 nM
The estimate for compound 4 lay 1.5-fold (0.19 log units) above the measured number, within the range that was stated.
By their numbers in this assay, from the lowest: compounds 4 and 3 (each within the scatter of the next); then compounds 1 and 2 (each within the scatter of the next).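

In this assay, among these compounds, the exchange of fluoro for trifluoromethyl on this aromatic carbon, para to a large group, is the only step that keeps the aryl ring, and a 1.3-fold lower number from compound 3 to compound 4 (0.12 log units; within the scatter) does not separate the two groups. The separation from the other aryl groups holds with trifluoromethyl too: a 3.2-fold lower number from compound 1 to compound 4 (0.50 log units; beyond the scatter) and a 5.2-fold lower number from compound 2 to compound 4 (0.71 log units; beyond the scatter) both lie beyond the scatter and are modest. No evidence on hand bears on these steps.

From the compounds shown here alone, whether an amine or a carboxylic acid on this same carbon would shift the number remains open. So does whether a longer chain there would do so.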